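The compounds below may be only part of what the source reports. "The series", "measured", "known", "first", "only" and "open" are said of these compounds alone.

Working notes on the series.

Three compounds sharing one core have been run in an ADME assay on microsomes from liver (Homo sapiens) for metabolic stability, tested at 2.5 uM; a higher number here means faster removal of the compound, a lower number slower removal. Compound 1 `O=S(=O)(c1ccc(F)c(Cl)c1)c1cnc2cc(F)ccc2c1-c1ccc(Cl)cc1` gives 0.39 mL/min; compound 2 `O=S(=O)(c1cccc(F)c1)c1cnc2cc(F)ccc2c1-c1ccc(Cl)cc1` gives 0.98 mL/min; compound 3 `Cc1ccc(S(=O)(=O)c2cnc3cc(F)ccc3c2-c2cccc(Cl)c2)cc1C` gives 4.01 mL/min. Going by the values given here, the only single-point step among them is a 2.5-fold higher number from compound 1 to compound 2 (0.40 log units; beyond the scatter). Among the compounds with values here, compound 3 stands highest of the three numbers, above compound 2 and above compound 1 by margins beyond the scatter, so it is the fastest-removed compound measured so far.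

The next compound, compound 4 `Cc1ccc(S(=O)(=O)c2cnc3cc(F)ccc3c2-c2ccc(Cl)cc2)cc1C`, is built from compound 3 with the same atoms joined differently: 4-chlorophenyl in place of 3-chlorophenyl on an aromatic carbon. Within the data shown here, the change sits on the aromatic carbon that carries the pendant ring, not on the sulfonyl sulfur, so the one measured step, from compound 1 to compound 2, does not bear on it directly. Compounds 1 and 2 already carry the 4-chlorophenyl at this position and both sit well below compound 3, but each also carries a different group on the sulfonyl sulfur, so their values alone cannot be ascribed to the pendant ring. Among the measured compounds shown here, with no step that isolates this change, the expectation for this assay is a step of a 1.1-fold lower number from compound 3 to compound 4 (0.06 log units; within the scatter), that is, nothing beyond the scatter. The estimate for compound 4 is therefore 3.5 mL/min, with a range from 1.5 mL/min to 8 mL/min.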

Compound 4, intrinsic clearance in a liver preparation (reported as CLH), per the amount of preparation that the assay uses: 7.88 mL/min
The estimate for compound 4 lay 2.3-fold (0.35 log units) below the measured number, within the range that was stated.
By their numbers in this assay, from the lowest: compound 1; then compound 2; then compounds 3 and 4 (each within the scatter of the next).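

Under this assay, 4-chlorophenyl in place of 3-chlorophenyl on the aromatic carbon opposite the ring nitrogen gives a 2.0-fold higher number from compound 3 to compound 4 (0.29 log units; within the scatter) and so leaves the two compounds indistinguishable, the first direct reading of this position in the series. With the 4-chlorophenyl held constant, the group on the sulfonyl sulfur can now be read on its own: 3,4-dimethylphenyl in place of 3-fluorophenyl gives an 8.0-fold higher number from compound 2 to compound 4 (0.91 log units; beyond the scatter) while 3,4-dimethylphenyl in place of 3-chloro-4-fluorophenyl gives a 20-fold higher number from compound 1 to compound 4 (1.31 log units; beyond the scatter) and both steps lie beyond the scatter, so among these four compounds the clear differences follow the sulfonyl substituent and not the placement of the chlorine. Nothing measured here bears on why either change has the size it has.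

From the compounds shown here alone, whether the placement of the chlorine stays as silent with 3-fluorophenyl or 3-chloro-4-fluorophenyl on the sulfonyl sulfur remains open, since only the 3,4-dimethylphenyl pair isolates it. Also open, going by these compounds, is how this position responds to a group other than a chlorophenyl, such as a pyridine ring, a methoxyphenyl or a phenyl carrying an amine or a carboxylic acid.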